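The source may report more compounds than this note shows. Statements on the series, on what has been measured and on what is new or still open speak of the compounds shown alone.

Measured compounds:
compound 1 `COc1cc(C)cc(-c2c(-c3ccnc(-c4ccc(N(C)C)cc4)c3)cnn2CC#N)c1`: 98%
compound 2 `COc1cc(C)cc(-c2nn(CC#N)cc2-c2ccnc(-c3ccc(N(C)C)cc3)c2)c1`: 95%
compound 3 `COc1cc(C)cc(-c2nn(CC#N)cc2-c2ccc(-c3cccc(C(C)=O)c3)nc2)c1`: 93%

In a functional assay on ACHN cells (Homo sapiens) for cytotoxicity, read by sulforhodamine B assay, with a stated time of 48 h, tested at 0.001 uM (on this read-out lower numbers stand for a stronger effect and higher numbers for a weaker effect at the one concentration tested), compound 2 gives 95%. That number is the second highest of the three shown, yet its nearest neighbour, compound 3, lies only a few points lower and compound 1 only a few points higher, so all three stand within the usual scatter of one another and no order among them can be claimed. Compound 4 `Cc1cc(O)cc(-c2nn(CC#N)cc2-c2ccnc(-c3ccc(N(C)C)cc3)c2)c1` has not been measured in this assay. It differs from compound 2 by hydrogen in place of methyl on an oxygen on an aromatic ring. Among the compounds with values here, no step between two measured compounds probes this kind of change, so the expectation rests on the narrow band the three measured compounds occupy. The step expected from compound 2 to compound 4 is no change at the digits printed from compound 2 to compound 4 (within the scatter), none beyond the scatter, in this assay. Compound 4 is therefore estimated at 95%, between 85% and 103%.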

Compound 4, a percentage reported as activity, at one concentration (the size of the read-out at that concentration, not a potency): 94%
Compound 4: middle estimate off by 1 percentage points, on the high side, within the range that was stated.
By their numbers in this assay, from the lowest: compounds 3, 4, 2 and 1 (each within the scatter of the next).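

Replacing methoxy with hydroxy on the aromatic ring gives a number 1 percentage points lower from compound 2 to compound 4 (within the scatter) in this assay. Within the data shown here, this is the first comparison of compounds that differ in one place, and it shows that, at this single concentration, hydrogen can stand in place of methyl on this oxygen without a step beyond the scatter. No available evidence explains this result.

The compounds shown leave open how an ethyl group on that oxygen or an amine in its place would read. They also leave open whether this change would separate from the scatter at another concentration.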